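This account rests on a few compounds, and the source may have more. Where it says the series, first, only, none or still open, it means among the compounds named here.

Notes on the series sharing the core of compound 1 `CC1CCN(c2ccc3cc(NC(=O)CCc4ccc(C(F)(F)F)cc4)ccc3n2)C1`. In a functional assay on HEK293 cells for activation of melanin-concentrating hormone receptor 1 (Rattus norvegicus), read by inositol phosphate accumulation (on this read-out higher numbers stand for an effect only at larger amounts of compound and lower numbers for an effect already at smaller amounts), compound 1 gives 400 nM. Compound 2 `O=C(CCc1ccc(C(F)(F)F)cc1)Nc1ccc2nc(N3CCCC3)ccc2c1` in this assay gives 320 nM; 320 nM (2 entries), recorded as two entries. Compound 3 `CC(=O)NC1CCN(c2ccc3cc(NC(=O)CCc4ccc(C(F)(F)F)cc4)ccc3n2)C1` in this assay gives 440 nM. Among the compounds with values here, compound 3 thus carries the highest of the two single numbers, with compound 1 nearest; the only measured step, a 1.1-fold higher number from compound 1 to compound 3 (0.04 log units; within the scatter), is within the scatter, so the two compounds cannot be ordered. Compound 2 has no single number, but both of its entries lie close to the numbers of compound 1 and compound 3.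

Compound 4 `O=C(CCc1ccc(C(F)(F)F)cc1)Nc1ccc2nc(N3CCCCC3)ccc2c1` is not yet measured. piperidin-1-yl in place of 3-acetamidopyrrolidin-1-yl on an aromatic carbon The step of a 1.1-fold higher number from compound 1 to compound 3 (0.04 log units; within the scatter) shows that exchanging the group on the saturated ring leaves the number within the scatter. Within the data shown here, no measured step covers the change from a five-membered to a six-membered ring, nor the loss of the acetamido group itself; compound 2, which carries an unsubstituted five-membered ring at the same position, shows entries near the other two numbers. No step beyond the scatter is therefore expected in this assay for compound 4, the expected step being a 1.3-fold lower number from compound 3 to compound 4 (0.10 log units; within the scatter). Compound 4 is estimated at 350 nM in this assay, with a range from 150 nM to 900 nM.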

Compound 4, half-maximal effective concentration: 110 nM
Compound 4: the middle estimate sits 3.2-fold (0.50 log units) above what was measured; the measured number lies below the stated range.
By their numbers in this assay, from the lowest: compound 4; then compounds 1 and 3 (each within the scatter of the next).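

Piperidin-1-yl on the aromatic carbon next to the ring nitrogen moves the number in this assay beyond the scatter, from either five-membered ring compound (a 4.0-fold lower number from compound 3 to compound 4 (0.60 log units; beyond the scatter); a 3.6-fold lower number from compound 1 to compound 4 (0.56 log units; beyond the scatter)), and both steps are modest. The earlier exchange on the saturated ring, 3-acetamido for 3-methyl, did not separate compound 1 and compound 3 (a 1.1-fold higher number from compound 1 to compound 3 (0.04 log units; within the scatter)), so this position responds to a change in the ring itself, not only to a change in what the five-membered ring carries. Each new step changes ring size and ring substituent together, compound 2 gives two entries (320 nM; 320 nM (2 entries)) and no single number, so steps to it cannot be read, and no measurement at hand explains the lower number of compound 4.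

Open, as far as these compounds go, is whether the six-membered ring alone carries the step, which a 4-acetamidopiperidin-1-yl or 4-methylpiperidin-1-yl group at this position would test. Also open, from the compounds shown here alone, is whether the trend continues to a seven-membered azepan-1-yl ring or survives a ring oxygen, as in morpholin-4-yl.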